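The source may hold more compounds than are shown below. What is called first, only, known or untested is meant among the compounds shown, and "the series" means these compounds.

Among the compounds with values here, compound 2 `CCCCCCN1CCN(CCC(=O)Nc2nc3c(C)cccc3s2)CC1` gives the lowest of the two numbers so far in an assay on membranes from brain for displacement of a labelled ligand from Sigma non-opioid intracellular receptor 1 (Cavia porcellus), read by scintillation counting, with a stated time of 120 min; a lower number here means a stronger inhibitor, a higher number a weaker inhibitor: compound 2 shows 238 nM, while compound 1 `Cc1cccc2sc(NC(=O)CCN3CCN(C(C)C)CC3)nc12` shows 1300 nM, and the step of a 5.5-fold lower number from compound 1 to compound 2 (0.74 log units; beyond the scatter) lies beyond the scatter. Compound 3 `Cc1cccc2sc(NC(=O)CCN3CCN(c4ccncc4)CC3)nc12` differs from compound 2 in one place (pyridin-4-yl in place of hexyl on an amine nitrogen in a ring), so the group on that ring nitrogen is again changed, but this time from a chain to a ring of the same heavy-atom count with one hydrogen-bond acceptor. Within the data shown here, the only measured step that bears on this position is a 5.5-fold lower number from compound 1 to compound 2 (0.74 log units; beyond the scatter), and it shows that what sits on that nitrogen moves this assay by a modest amount. Among the measured compounds shown here, since no measured compound carries an aromatic group there, the direction is uncertain; the loss of the hexyl chain is expected to cost some of what compound 2 gained, giving an expected step of a 3.4-fold higher number from compound 2 to compound 3 (0.53 log units; beyond the scatter). Compound 3 is therefore estimated at 800 nM, within a range of 250 nM to 2500 nM.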

Compound 3, inhibition constant: 9600 nM
Estimate against measurement, compound 3: 12-fold (1.08 log units) below; the whole stated range lies below it.
By their numbers in this assay, from the lowest: compound 2; then compound 1; then compound 3.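

The step of a 40-fold higher number from compound 2 to compound 3 (1.61 log units; beyond the scatter) in this assay is large, so this position can move the number much further than the change from isopropyl to hexyl had shown. Pyridin-4-yl does more than give back what hexyl gained, since the step of a 7.4-fold higher number from compound 1 to compound 3 (0.87 log units; beyond the scatter) places it behind isopropyl as well, and among these three compounds both open-chain groups stand ahead of the aromatic ring. Hexyl and pyridin-4-yl have the same count of heavy atoms, so that count alone does not set the number here.

No measurement at hand accounts for this loss. On these data alone, it remains open whether the loss goes with the aromatic ring or with its ring nitrogen, and how a phenyl group, a benzyl group or a chain longer than hexyl on that nitrogen would compare.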